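Notes on fluorine changes in a small antiproliferative series

This account rests on a few compounds, and the source may have more. Where it says the series, first, only, none or still open, it means among the compounds named here.

Measured so far in a functional assay on KYSE-70 cells for antiproliferative activity against KYSE-70 cell line (Homo sapiens), read by MTT assay, with a stated time of 72 h; a higher number here means a weaker inhibitor, a lower number a stronger inhibitor:
- compound 2, `O=C(Nc1cccc(F)c1)c1cc(=O)[nH]c2cc(Br)ccc12`, gives 8900 nM.
- compound 1, `O=C(Nc1cc(F)ccc1F)c1cc(=O)[nH]c2cc(Br)ccc12`, gives only a limit of the assay, > 20000 nM.
- compound 3, `O=C(Nc1cccc(F)c1)c1cc(=O)[nH]c2cc(F)ccc12`, likewise gives only a limit, > 20000 nM.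

Compound 4, `O=C(Nc1cc(F)cc(F)c1)c1cc(=O)[nH]c2cc(F)ccc12`, is not yet measured.

Two steps are in hand. From compound 2 to compound 1 the change is fluoro in place of hydrogen on an aromatic carbon, giving an at least 2.2-fold higher number from compound 2 to compound 1 (0.35 log units; beyond the scatter). The two cores differ by fluoro in place of bromo on an aromatic carbon, with an at least 2.2-fold higher number from compound 2 to compound 3 (0.35 log units; beyond the scatter). Compound 4 arises from compound 3 by fluoro in place of hydrogen on an aromatic carbon; this is the same kind of change as that from compound 2 to compound 1, though the place differs: there the entering fluoro sits ortho to a large group and para to a fluoro group, here meta to a fluoro group and meta to a large group. Going by these compounds, both measured steps run into (the limit of > 20000 nM in this assay, at which 2 of the 3 values shown sit), so their full size is unknown.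

For compound 4 in this assay a step that the limit leaves unreadable from compound 3 to compound 4 is expected, resting on an at least 2.2-fold higher number from compound 2 to compound 1 (0.35 log units; beyond the scatter) and on compound 3 already sitting at the limit of > 20000 nM in this assay, at which 2 of the 3 values shown sit. Compound 4 is therefore estimated at about 35000 nM, probably reported again only as a limit, within 15000 nM to 100000 nM.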

Compound 4, half-maximal inhibitory concentration: > 20000 nM
Compound 4: a limit, no number (the forecaster's own chance of this, stated with the estimate: 90%); the middle value lies beyond the limit too.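

Compound 3 and compound 4 both stand only at a limit in this assay, so no size can be read for the step between them: the limit of > 20000 nM in this assay, at which 3 of the 4 values shown sit.

The compounds shown leave open whether fluoro in place of hydrogen on an aromatic carbon changes activity at all on the core shared by compound 3 and compound 4.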